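A few compounds are considered here, and "the series" means these few. Any claim that something is new, unique, unknown or untested is made for them only; others in the source may bear on it.

Working notes on the series. In a functional assay on MDA-MB-231 cells (Homo sapiens) for antiproliferative activity, read by MTT assay, with a stated time of 72 h (a lower number here means a stronger inhibitor, a higher number a weaker inhibitor), compound 1 `CC1=CC[C@H]2[C@@H]1CC=C(C)[C@@H](CC[C@H]1[C@]3(C)CC[C@H](OC(=O)c4ccc(C)cc4)C(C)(C)O[C@H]3CC[C@@]1(C)O)C2(C)C` gives 32700 nM. Compound 2 `CC1=CC[C@H]2[C@H](CC[C@]2(C)O)C(C)(C)[C@@H]1CC[C@H]1[C@]2(C)CC[C@H](OCc3ccccc3)C(C)(C)O[C@H]2CC[C@@]1(C)O` gives 29100 nM, which lies within the usual scatter of the value for compound 1, so the two numbers cannot be ranked.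

The next compound to be read is compound 3 `CC1=CC[C@H]2[C@H](CC[C@]2(C)O)C(C)(C)[C@@H]1CC[C@H]1[C@]2(C)CC[C@H](OC(=O)c3ccc(Cl)c(Cl)c3)C(C)(C)O[C@H]2CC[C@@]1(C)O`. It follows from compound 2 by one change on the shared core: (3,4-dichlorophenyl)carbonyl in place of benzyl on an oxygen on a saturated carbon. In words, (3,4-dichlorophenyl)carbonyl stands in place of benzyl on an oxygen on a saturated carbon.

Within the data shown here, the series holds no measured step in which only one place differs, so the size of this exchange has no direct precedent. Among the measured compounds shown here, the only guide is that compound 1 at 32700 nM and compound 2 at 29100 nM sit within the scatter of each other. On that basis, no step beyond the scatter is expected in this assay, in either direction, although a wide margin is needed. The estimated change is a 1.2-fold lower number from compound 2 to compound 3 (0.07 log units; within the scatter). For compound 3 the estimated value is 25000 nM, with an expected range of 10000 nM to 55000 nM.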

Compound 3, half-maximal inhibitory concentration: 8100 nM
Compound 3: middle estimate off by 3.1-fold (0.49 log units), on the high side; measured number outside the range, below it.
By their numbers in this assay, from the lowest: compound 3; then compounds 2 and 1 (each within the scatter of the next).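

In this assay the series shows a 3.6-fold lower number from compound 2 to compound 3 (0.56 log units; beyond the scatter) and this is its first step beyond the scatter, so the substituent on an oxygen on a saturated carbon can move the number, though only modestly here. The exchange replaces benzyl, with no hydrogen-bond acceptor, by (3,4-dichlorophenyl)carbonyl, with one, while a six-membered aromatic ring of carbon only is present on both sides, so the carbonyl and the two chlorines enter together and this single step cannot separate them. No measurement shown here accounts for the size or the direction of the step.

Still open, as far as these compounds go, is which part of the exchange carries the step: an unsubstituted benzoyl group would isolate the carbonyl, and a 3,4-dichlorobenzyl group would isolate the chlorines, each on the same oxygen and the same core as compound 3. Also open, from the compounds shown here alone, is whether the position accepts groups of a different kind, such as a simple acetyl group, a longer alkyl chain or a chain ending in an amine or a carboxylic acid, since both groups compared here carry an aromatic ring.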